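A few compounds are considered here, and "the series" means these few. Any claim that something is new, unique, unknown or untested is made for them only; others in the source may bear on it.

Compound 1, `COc1cccc(CNCCCNc2ccnc3cc(Oc4ccccc4)ccc23)c1O`, gives 9.28 in a physicochemical assay for acid dissociation. Compound 2, `Fc1ccc(Oc2ccc3c(NCCCNCc4ccco4)ccnc3c2)cc1`, gives 9.28 in this assay, and compound 3, `c1ccc(Oc2ccc3c(NCCCNCc4ccco4)ccnc3c2)cc1`, gives 9.28. Compound 1 thus stands level with compounds 2 and 3 at the digits shown, compound 2 being its nearest neighbour and compound 3 its furthest, both within the scatter. Two steps are known: no change at the digits printed from compound 1 to compound 3 (within the scatter), and no change at the digits printed from compound 2 to compound 3 (within the scatter). Neither an exchange on the saturated chain carbon bound to the amine nitrogen nor an exchange on an aromatic carbon moved the number beyond the scatter.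

Compound 4, `CCC(CC)c1ccc2c(NCCCNCc3cccc(OC)c3O)ccnc2c1`, differs from compound 1 in one place: pentan-3-yl in place of phenoxy on an aromatic carbon. Within the data shown here, no measured step exchanges phenoxy for pentan-3-yl, so the two known steps bear only by analogy. Both were flat, and the change in compound 4 lies on an aromatic carbon of the core, far from the amine nitrogens that hold the proton. The author therefore expects no step beyond the scatter, no change at the digits printed from compound 1 to compound 4 (within the scatter), and estimates for compound 4 a value of 9.28, within 8.9 to 9.65.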

Compound 4, acid dissociation constant: 9.47
Compound 4: middle estimate off by 0.19 log units, on the low side, and the stated range covers the measured number.
By their numbers in this assay, from the lowest: compounds 1, 2, 3 and 4 (each within the scatter of the next).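

In this assay, among these compounds, the aromatic carbon that carries phenoxy in compound 1 tolerates a much larger exchange than the earlier steps tested: the step reads a number 0.19 log units higher from compound 1 to compound 4 (within the scatter) even though an aromatic ring and a hydrogen-bond acceptor leave and the ringless pentan-3-yl enters. Among the compounds shown here, the earlier steps covered only a fluoro on an aromatic carbon and the group on the saturated chain carbon, so this is the first sign that the whole phenoxy can go without moving the number beyond the scatter. No measurement offered here accounts for this flat result.

Going by these compounds, what remains open is whether an amine or a carboxylic acid on this aromatic carbon would move the number beyond the scatter. The same question stands for a longer chain in place of the one that carries the amine nitrogen.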